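The source may hold more compounds than are shown below. What is called first, only, known or untested is meant among the compounds shown, and "the series" means these compounds.

Working notes on the series. Compound 1 `Cc1ccc(C(=O)NCN2CCC(c3cccc[n+]3[O-])CC2)cc1C` holds the lowest number among the three compounds measured in a functional assay on HEK293 cells for agonist activity at D(4) dopamine receptor (Homo sapiens), read by FLIPR; a lower number here means that less compound is needed, a higher number that more compound is needed for the effect: compound 1 gives 38 nM. Its nearest neighbour on the numbers is compound 2 `Cc1ccc([N+](=O)[O-])cc1NC(=O)CN1CCC(c2cccc[n+]2[O-])CC1`, which in this assay gives 134 nM, a step beyond the usual scatter. Furthest from compound 1 is compound 3 `Cc1cccc(NC(=O)CN2CCC(c3cccc(F)c3)CC2)c1`, which in this assay gives 512 nM, also beyond the scatter. The three measured compounds do not form any pair that differs in a single place, so none of these gaps can be tied to one structural change.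

Compound 4 `Cc1cc(C(=O)NCN2CCC(c3cccc[n+]3[O-])CC2)ccc1Cl` is the next compound in line and differs from compound 1 in one place: chloro in place of methyl on an aromatic carbon. Among the measured compounds shown here, no measured pair in the set shows what this exchange does, so the expectation rests on the change being a single-atom swap on the outer ring of the shared core, away from the parts that are common to all four compounds. The expected step is small, in either direction, and most likely within the scatter. For compound 4 in this assay the estimate is 45 nM, with a range from 20 nM to 110 nM, which as a step means an expected 1.2-fold higher number from compound 1 to compound 4 (0.07 log units; within the scatter).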

Compound 4, half-maximal effective concentration: 2460 nM
Compound 4: the middle estimate sits 55-fold (1.74 log units) below what was measured; the whole stated range lies below it.
By their numbers in this assay, from the lowest: compound 1; then compound 2; then compound 3; then compound 4.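

In this assay, among the compounds shown here, this is the first step that can be tied to one place, and the exchange of methyl for chloro, ortho to a methyl group and para to a large group, gives a 65-fold higher number from compound 1 to compound 4 (1.81 log units; beyond the scatter) on the aromatic ring of the shared core. Methyl and chloro each count as one heavy atom, with no ring, no hydrogen-bond donor or acceptor and no net charge, so these counts do not separate the two compounds, yet a change of one atom at this position is enough for a large step. Nothing available accounts for the size of this step.

Whether the step reflects the arrival of chloro or the departure of methyl stays open, since the compounds shown carry no hydrogen, fluoro, bromo, methoxy or ethyl at this position to separate the two readings. Also open, from the compounds shown here alone, is whether the 3,4-dimethylphenyl to 4-chloro-3-methylphenyl exchange gives a step of similar size on any core other than that of compound 1.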